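Anilino Series: Fluoro for Hydrogen on the Aryl Ring

The source may hold more compounds than are shown below. What is called first, only, known or untested is meant among the compounds shown, and "the series" means these compounds.

Two compounds on the shared core have numbers in a functional assay on MCF7 cells (Homo sapiens) for cytotoxicity, read by sulforhodamine B assay; a lower number here means a stronger inhibitor, a higher number a weaker inhibitor. Compound 1 `C=C1[C@@H](OC(C)=O)C[C@@H]2[C@](C)(COC=O)[C@H](OC(C)=O)CC[C@@]2(C)[C@@H]1C[C@@H](Nc1ccc(C(=O)O)cc1)C1=CCOC1=O` gives 41700 nM in this assay. Compound 2 `C=C1[C@@H](OC(C)=O)C[C@@H]2[C@](C)(COC=O)[C@H](OC(C)=O)CC[C@@]2(C)[C@@H]1C[C@@H](Nc1ccccc1)C1=CCOC1=O` gives 26200 nM in this assay, the lowest of the two numbers, though only a 1.6-fold lower number from compound 1 to compound 2 (0.20 log units; within the scatter) separates it from compound 1, so the two cannot be ordered. For the measured compounds named here, the step between them, hydrogen in place of carboxy on an aromatic carbon, is the only measured step on the anilino ring and did not move the number beyond the scatter.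

Compound 3 `C=C1[C@@H](OC(C)=O)C[C@@H]2[C@](C)(COC=O)[C@H](OC(C)=O)CC[C@@]2(C)[C@@H]1C[C@@H](Nc1ccc(F)cc1)C1=CCOC1=O` is not yet measured. It differs from compound 2 by fluoro in place of hydrogen on an aromatic carbon at the same aromatic carbon that the carboxy occupied in compound 1. Going by the values given here, the one step that bears on this position, a 1.6-fold lower number from compound 1 to compound 2 (0.20 log units; within the scatter), was within the scatter, so no step beyond the scatter is expected for this change in either direction, with the caveat that a single step is a thin basis. Compound 3 is therefore expected to give 26000 nM in this assay, within 10000 nM to 65000 nM, which means an expected step of a 1.0-fold lower number from compound 2 to compound 3 (0.00 log units; within the scatter).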

Compound 3, half-maximal inhibitory concentration: 12400 nM
Estimate against measurement, compound 3: 2.1-fold (0.32 log units) above; low and high end bracket the measured number.
By their numbers in this assay, from the lowest: compound 3; then compounds 2 and 1 (each within the scatter of the next).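

For the compounds shown here, on this aromatic carbon, para to a large group, fluoro in place of hydrogen gives a 2.1-fold lower number from compound 2 to compound 3 (0.32 log units; beyond the scatter) in this assay and is the first change on the anilino ring to lie beyond the scatter, so the position is not indifferent to substitution, as the earlier pair alone could have suggested. Fluoro in place of carboxy at the same carbon gives a 3.4-fold lower number from compound 1 to compound 3 (0.53 log units; beyond the scatter) and thus separates compound 3 from both earlier compounds, though compound 1 and compound 2 still cannot be ordered and both new steps are only modest. Nothing at hand accounts for this difference between fluoro and the other two substituents at this carbon.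

Whether the step is particular to fluoro stays open, since the compounds shown include no chloro, bromo, methoxy or amine at this carbon to set beside it. Also open, as far as these compounds go, is whether fluoro on another carbon of the ring, or more than one fluoro, would give a step of similar size or direction in this cell line or in any other.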